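This account rests on a few compounds, and the source may have more. Where it says the series, first, only, none or still open, it means among the compounds named here.

Compound 1 `COc1ncnc2c1c(-c1ccsc1)cn2[C@@H]1O[C@H](CO)[C@@H](O)[C@H]1O` carries a methoxy group on the shared core. Within the data shown here, in a functional assay on HCT-116 cells (Homo sapiens), read by MTT assay, with a stated time of 72 h (on this read-out higher numbers stand for weaker inhibition and lower numbers for stronger inhibition), compound 1 gives 120 nM, the only actual number reported for the series. Among the measured compounds shown here, compound 2 `CN(C)c1ncnc2c1c(-c1ccsc1)cn2[C@@H]1O[C@H](CO)[C@@H](O)[C@H]1O` is the only other compound measured. In this assay compound 2 reaches only the assay limit of > 20000 nM, so no number is available for it. For the measured compounds named here, the step of an at least 160-fold higher number from compound 1 to compound 2 (2.22 log units; beyond the scatter) is the single measured comparison; since it rests on (the limit of > 20000 nM in this assay, at which 1 of the 2 values shown sits), its true size is known only to be large. Compound 3 `COc1nc(N)nc2c1c(-c1ccsc1)cn2[C@@H]1O[C@H](CO)[C@@H](O)[C@H]1O` keeps the methoxy of compound 1 and differs by amino in place of hydrogen on an aromatic carbon. The measured step bears on compound 3 only loosely: it concerns replacement of the methoxy itself, whereas compound 3 retains the methoxy and instead gains an amino group at the position described. Going by the values given here, no measured step covers the addition of an amino group, so no direction is taken from compound 2. Without a measured analogue, a small step is expected, a 1.7-fold higher number from compound 1 to compound 3 (0.22 log units; within the scatter), within or near the scatter. Compound 3 is estimated at 200 nM in this assay, between 40 nM and 1500 nM.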

Compound 3, half-maximal inhibitory concentration: > 20000 nM
Compound 3 was reported as a limit; the forecaster's own chance of this, stated with the estimate: 10%; middle value at least 100-fold (2.00 log units) from the limit.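

In this assay, the position between two ring nitrogen atoms, which carries hydrogen in compound 1, turns out to be sensitive: with the methoxy group kept, amino in place of hydrogen gives an at least 160-fold higher number from compound 1 to compound 3 (2.22 log units; beyond the scatter). Among these compounds, until now the only large step lay at the methoxy group, through an at least 160-fold higher number from compound 1 to compound 2 (2.22 log units; beyond the scatter), so a loss of this kind on the shared core is no longer tied to replacing the methoxy group. Compound 3 stands at a limit, so the new step has a known minimum but no known true size, and the same holds for the earlier step: the limit of > 20000 nM in this assay, at which 2 of the 3 values shown sit.

Going by these compounds, whether the step belongs to amino specifically or to any group at this position stays open, and a methyl group or a fluorine atom there would bear on that question. Also open, on these data alone, is how far the methoxy group itself can vary, for instance with an ethoxy group or a methylamino group in its place, the latter lying closer to the methoxy group in size than the dimethylamino group of compound 2.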